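The source may hold more compounds than are shown below. What is called first, only, known or untested is meant among the compounds shown, and "the series" means these compounds.

Compound 1 `CCNc1cc(-c2ccc(NC(=O)Nc3ccc(C(F)(F)F)cc3)cc2C(F)(F)F)ccn1`: 82.9% in an assay on isolated protein for inhibition of serine/threonine-protein kinase PLK1 (Homo sapiens), read by radiometric assay and 33P incorporation, with a stated time of 40 min, tested at 20 uM, in the presence of a further agent that is not named here; on this read-out lower numbers stand for less inhibition and higher numbers for more inhibition at the one concentration tested (going by the name of the read-out)
Compound 2 `O=C(Nc1cccc(Cl)c1)Nc1ccc(-c2ccnc(NCC3CC3)c2)c(C(F)(F)F)c1`: 63.8%
Compound 3 `O=C(Nc1ccc(C(F)(F)F)cc1)Nc1ccc(-c2ccnc(NCC3CC3)c2)c(C(F)(F)F)c1`: 53.4%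

Compound 3 stands lowest of the three measured compounds. The step of a number 10.4 percentage points lower from compound 2 to compound 3 (beyond the scatter) and the step of a number 29.5 percentage points lower from compound 1 to compound 3 (beyond the scatter) both end at compound 3 and both lie beyond the scatter. Compound 4 `CCCNc1cc(-c2ccc(NC(=O)Nc3ccc(C(F)(F)F)cc3)cc2C(F)(F)F)ccn1` differs from compound 3 by ethyl in place of cyclopropyl on a saturated chain carbon bound to a nitrogen on an aromatic ring. The step of a number 29.5 percentage points lower from compound 1 to compound 3 (beyond the scatter) alters the same group at the same place and so bears directly on this change; the step of a number 10.4 percentage points lower from compound 2 to compound 3 (beyond the scatter) touches another part of the molecule and does not. Compound 1, carrying methyl at that place, gave the highest value, so a rise of modest size is expected for compound 4, with uncertain extent. Compound 4 is estimated at 68%, between 52% and 84%, an expected step of a number 14.6 percentage points higher from compound 3 to compound 4 (beyond the scatter).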

Compound 4, a percentage reported as inhibition, at one concentration (the size of the read-out at that concentration, not a potency): 51.3%
Compound 4: middle estimate off by 16.7 percentage points, on the high side; measured number outside the range, below it.
By their numbers in this assay, from the lowest: compounds 4 and 3 (each within the scatter of the next); then compound 2; then compound 1.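

Opening the ring leaves the read-out unmoved, with ethyl in place of cyclopropyl giving a number 2.1 percentage points lower from compound 3 to compound 4 (within the scatter), so a plain chain at this place does no better than the ring-bearing group. The sensitive feature is instead the size of the chain: methyl in place of hydrogen on the chain gives a number 31.6 percentage points lower from compound 1 to compound 4 (beyond the scatter), a large loss from one added carbon. Nothing measured here explains this loss.

The compounds shown leave open whether a shorter methylamino group or a free amine would hold or raise the number. They also leave open whether a longer chain such as butyl would lower it further.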